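A plain phenyl in place of a substituted ring

A few compounds are considered here, and "the series" means these few. Any claim that something is new, unique, unknown or untested is made for them only; others in the source may bear on it.

Values from an ADME assay on HEK293 cells (Homo sapiens) for cytotoxicity, read by reporter gene assay and resazurin assay, with a stated time of 48 h (on this read-out higher numbers stand for lower toxicity in this test and lower numbers for higher toxicity in this test), are as follows.
Compound 1 `COc1c(Br)cc(Br)cc1C(=O)Nc1ccccc1` reads > 100000 nM as a limit
Compound 2 `COc1ccc(Br)cc1C(=O)Nc1ccc(Sc2nc3ccccc3s2)cc1` reads > 100000 nM as a limit
Compound 3 `O=C(Nc1ccc(Sc2nc3ccccc3s2)c(Cl)c1)c1cccc(Br)c1O` reads 64000 nM as a number

Compound 2 stands at the limit of > 100000 nM in this assay, at which 2 of the 3 values shown sit, and its reading is a limit and not a number. In compound 4 `O=C(Nc1ccc(Sc2nc3ccccc3s2)cc1)c1ccccc1` phenyl takes the place of 5-bromo-2-methoxyphenyl on a carbonyl carbon (phenyl in place of 5-bromo-2-methoxyphenyl on a carbonyl carbon) while the rest of compound 2 stays the same. Among the measured compounds shown here, no measured pair shows this change on its own, so any expectation here rests on little. For the measured compounds named here, the only true number comes from compound 3 (64000 nM) and it gives no sign of a large shift, so no step beyond the usual scatter is expected in this assay for this change. The expected change is a number no higher from compound 2 to compound 4 (the limit leaves the size open) and no clear direction is foreseen. Compound 4 may well read as a limit too. For compound 4 the estimate is 100000 nM with an expected range from 40000 nM to 250000 nM in the same test.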

Compound 4, half-maximal cytotoxic concentration: > 100000 nM
Compound 4: no number, only a limit; the forecaster's own chance of this, stated with the estimate: 65%; the middle value lies on the limit itself.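

Compound 2 and compound 4 both read as limits and not as numbers, so the step between them cannot be read: the limit of > 100000 nM in this assay, at which 3 of the 4 values shown sit.

The compounds shown leave open whether phenyl in place of 5-bromo-2-methoxyphenyl on a carbonyl carbon changes toxicity in this test at all.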